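This account rests on a few compounds, and the source may have more. Where it says the series, first, only, none or still open, it means among the compounds named here.

Notes on the series. In a functional assay on RAW264.7 cells (Mus musculus), with a stated time of 3 days (on this read-out lower numbers stand for stronger inhibition and higher numbers for weaker inhibition), compound 1 (`COc1cnc(-c2ccccn2)nc1NCc1ccccc1C`) gives 220 nM and compound 2 (`COc1cnc(-c2ccccn2)nc1NCc1ccccc1`) gives 420 nM so that compound 2 stands within the scatter of compound 1 on the two numbers available. Compound 3 (`COc1cnc(-c2ccccn2)nc1NCc1ccccc1F`) takes fluoro in place of hydrogen on an aromatic carbon of compound 2, ortho to a large group (fluoro in place of hydrogen on an aromatic carbon), the same difference reading phenyl to 2-fluorophenyl. Among the compounds with values here, one measured step bears on this: a 1.9-fold higher number from compound 1 to compound 2 (0.28 log units; within the scatter) for hydrogen in place of methyl on an aromatic carbon, a small step within the scatter. Within the data shown here, that is thin evidence, and no fluoro compound has been measured yet. No step beyond the scatter is therefore expected in this assay and no direction is favoured. The estimated step is a 1.3-fold lower number from compound 2 to compound 3 (0.10 log units; within the scatter) for this change. For compound 3 the expected value is 330 nM with a range from 150 nM to 750 nM.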

Compound 3, half-maximal inhibitory concentration: 130 nM
The estimate for compound 3 lay 2.5-fold (0.40 log units) above the measured number; the measured number lies below the stated range.
By their numbers in this assay, from the lowest: compounds 3, 1 and 2 (each within the scatter of the next, the first and the last beyond it).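

In this assay, within the data shown here, the change gives the first step at this position that lies beyond the scatter: a 3.2-fold lower number from compound 2 to compound 3 (0.51 log units; beyond the scatter) shows that fluoro in place of hydrogen on this aromatic carbon, ortho to a large group, does alter the number, which the methyl and hydrogen pair could not show. The substituents do not separate from each other, since a 1.7-fold lower number from compound 1 to compound 3 (0.23 log units; within the scatter) leaves fluoro and methyl at this position within the scatter, yet only fluoro stands beyond the scatter of the hydrogen compound, and compound 1 goes against any general rule that substitution here separates from hydrogen. Nothing at hand explains the step from hydrogen to fluoro.

From the compounds shown here alone, whether chloro, methoxy, an amine or a carboxylic acid on this same aromatic carbon would carry the number further than fluoro stays open. Also open, going by these compounds, is whether the fluoro step holds with the fluoro placed elsewhere on this ring, or on other read-outs.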